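The compounds below may be only part of what the source reports. "The series", "measured", "known", "first", "only" and "open" are said of these compounds alone.

The measured compounds:
compound 1 `COc1ccccc1N1CCN(CCCCCCN2C(=O)c3ccccc3S2(=O)=O)CC1` gives 105 nM in an assay on HEK293 cells for displacement of a labelled ligand from 5-hydroxytryptamine receptor 7 (Homo sapiens); a lower number here means a stronger inhibitor, a higher number a weaker inhibitor;
compound 2 `O=C1c2ccccc2S(=O)(=O)N1CCCCCCN1CCN(c2cccc(Cl)c2Cl)CC1` gives 487 nM;
compound 3 `O=C1c2ccccc2S(=O)(=O)N1CCCCCN1CCN(c2ncccn2)CC1` gives 2670 nM.

Compound 3 has the highest of the three numbers; compound 2 lies nearest to it and compound 1 furthest. Compound 4 `O=C1c2ccccc2S(=O)(=O)N1CCCCCN1CCN(c2cccc3ccccc23)CC1` differs from compound 3 in one place: naphthalen-1-yl in place of pyrimidin-2-yl on an amine nitrogen in a ring. Among the measured compounds shown here, no measured step exchanges the pyrimidin-2-yl group. For the measured compounds named here, the only step on the group carried by that ring nitrogen, a 4.6-fold higher number from compound 1 to compound 2 (0.67 log units; beyond the scatter), shows that such an exchange moves the number modestly. Both compounds with a carbon-only aromatic ring there sit far below compound 3, because compound 1 gives 105 nM and compound 2 gives 487 nM. Compound 4 is therefore expected to show a step of a 7.6-fold lower number from compound 3 to compound 4 (0.88 log units; beyond the scatter). The estimate for compound 4 is 350 nM, ranging from 80 nM to 1500 nM.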

Compound 4, inhibition constant: 36 nM
The estimate for compound 4 lay 9.7-fold (0.99 log units) above the measured number; the measured number lies below the stated range.
By their numbers in this assay, from the lowest: compound 4; then compound 1; then compound 2; then compound 3.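

Naphthalen-1-yl in place of pyrimidin-2-yl on the amine nitrogen in the ring gives a 74-fold lower number from compound 3 to compound 4 (1.87 log units; beyond the scatter) in this assay, so an exchange at this position can be large, whereas the earlier 4.6-fold higher number from compound 1 to compound 2 (0.67 log units; beyond the scatter) was modest. This change adds a second aromatic ring and removes both ring nitrogens at once, so the step cannot separate these two differences. No measurement here accounts for the size of the step.

Going by these compounds, it remains open how a phenyl or quinolinyl group would compare at this position on the chain of compound 4, and whether a longer chain would alter the number with naphthalen-1-yl in place.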